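A few compounds are considered here, and "the series" means these few. Any claim that something is new, unique, unknown or untested is made for them only; others in the source may bear on it.

Measured compounds and their values:
- compound 1, `CC(=O)c1cc(-c2ccccc2)cc2cc(-c3ccccc3)[nH]c12`: 65.8%
- compound 2, `CC(=O)c1cc(-c2ccc(F)cc2)cc2cc(-c3ccccc3)[nH]c12`: 36.4%
- compound 3, `COc1ccc(-c2cc(C(C)=O)c3[nH]c(-c4ccccc4)cc3c2)cc1`: 30.8%

All three were tested in a functional assay on MCF7 cells (Homo sapiens) for cytotoxicity, read by MTT assay, with a stated time of 2 days, tested at 100 uM; a lower number here means a stronger effect, a higher number a weaker effect of the compound at the concentration tested. Compound 1 stands highest of the three, meaning the weakest effect at the tested concentration; its nearest neighbour is compound 2, reached by a number 29.4 percentage points lower from compound 1 to compound 2 (beyond the scatter), and furthest is compound 3, reached by a number 35 percentage points lower from compound 1 to compound 3 (beyond the scatter). Between compound 2 and compound 3 the gap is a number 5.6 percentage points lower from compound 2 to compound 3 (within the scatter).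

The unmeasured compound 4, `CC(=O)c1cc(-c2ccccc2)cc2cc(-c3ccc(F)cc3)[nH]c12`, differs from compound 1 in one place: fluoro in place of hydrogen on an aromatic carbon. For the measured compounds named here, the fluoro here sits on the other phenyl ring of the shared core, not the one changed in compound 2 and compound 3.

Going by the values given here, the step that bears most closely on this change is the one from compound 1 to compound 2, a fluoro in place of hydrogen on an aromatic carbon, which gave a modest drop. Since compound 4 carries the same group on a different ring, that step is only a rough guide; a drop is expected in this assay, but a smaller or absent one cannot be ruled out. The expected step is a number 17.8 percentage points lower from compound 1 to compound 4 (beyond the scatter), and compound 4 is estimated at 48%, in a range from 25% to 72%.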

Compound 4, a percentage reported as activity, at one concentration (the size of the read-out at that concentration, not a potency): 73.3%
Estimate against measurement, compound 4: 25.3 percentage points below, and the stated range ends below it.
By their numbers in this assay, from the lowest: compounds 3 and 2 (each within the scatter of the next); then compounds 1 and 4 (each within the scatter of the next).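

On the phenyl ring changed in compound 4, going from phenyl to 4-fluorophenyl gives a number 7.5 percentage points higher from compound 1 to compound 4 (within the scatter) in this assay, so at this position the added fluoro leaves compound 4 indistinguishable from compound 1. For the compounds shown here, the same swap on the other phenyl ring gave a number 29.4 percentage points lower from compound 1 to compound 2 (beyond the scatter), so across these two steps the outcome of adding one fluoro depends on which ring carries it, something the earlier compounds, all changed on that other ring only, could not show. Nothing available here explains why the two rings behave differently.

Whether this ring responds to any substituent remains open: a single fluoro is the only change on it among these compounds, and a methoxy, an amine or a carboxylic acid in the same place could give a quite different reading. From the compounds shown here alone, each reading also comes from one concentration, so it gives the size of the effect at that concentration rather than a potency, and how compound 1 and compound 4 compare at lower concentrations remains unknown.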